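The compounds below may be only part of what the source reports. "The series", "measured", "known", "first", "only" and "open" are said of these compounds alone.

Series notes. Three measured compounds share one core and differ only in the group on an oxygen on a saturated carbon. Compound 1 `CC(C)[C@H](NC(=O)COc1cccc2ccccc12)C(=O)N[C@@H](CC(=O)O)C(=O)COc1ccc(-c2ccccc2)cc1` gives 38700 nM in a functional assay with Homo sapiens as the target (a higher number here means a weaker inhibitor, a lower number a stronger inhibitor), the highest of the three numbers. Compound 2 `CC(C)[C@H](NC(=O)COc1cccc2ccccc12)C(=O)N[C@@H](CC(=O)O)C(=O)COc1ccc([N+](=O)[O-])cc1` gives 22800 nM in this assay, and compound 3 `CC(C)[C@H](NC(=O)COc1cccc2ccccc12)C(=O)N[C@@H](CC(=O)O)C(=O)COc1ccc(F)cc1F` gives 17600 nM. The step of a 1.7-fold lower number from compound 1 to compound 2 (0.23 log units; within the scatter) stays within the scatter, whereas a 2.2-fold lower number from compound 1 to compound 3 (0.34 log units; beyond the scatter) is modest but beyond it; a 1.3-fold lower number from compound 2 to compound 3 (0.11 log units; within the scatter) is within the scatter.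

Compound 4 `CC(C)[C@H](NC(=O)COc1cccc2ccccc12)C(=O)N[C@@H](CC(=O)O)C(=O)COc1c(F)c(F)c(F)c(F)c1F` is not yet measured. It differs from compound 1 as follows: 2,3,4,5,6-pentafluorophenyl in place of 4-phenylphenyl on an oxygen on a saturated carbon. The step from compound 1 to compound 3 bears most directly on this change, since it also exchanges the 4-phenylphenyl for a fluorinated phenyl at the same place, giving a 2.2-fold lower number from compound 1 to compound 3 (0.34 log units; beyond the scatter). The step of a 1.7-fold lower number from compound 1 to compound 2 (0.23 log units; within the scatter), where nitro replaces phenyl on an aromatic carbon, stays within the scatter. A modest lowering of the number in this assay is therefore expected for compound 4, of about a 2.6-fold lower number from compound 1 to compound 4 (0.41 log units; beyond the scatter). Compound 4 is estimated at 15000 nM in this assay, with an expected range from 6000 nM to 40000 nM.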

Compound 4, half-maximal inhibitory concentration: 8890 nM
Compound 4: middle estimate off by 1.7-fold (0.23 log units), on the high side; the measured number falls inside the stated range.
By their numbers in this assay, from the lowest: compounds 4, 3, 2 and 1 (each within the scatter of the next, the first and the last beyond it).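

In this assay the change to 2,3,4,5,6-pentafluorophenyl on the oxygen on a saturated carbon gives the largest step from compound 1 in the series, a 4.4-fold lower number from compound 1 to compound 4 (0.64 log units; beyond the scatter), and with a 2.6-fold lower number from compound 2 to compound 4 (0.41 log units; beyond the scatter) it also gives the first step from compound 2 that lies beyond the scatter. The two fluorinated phenyl groups are not separated at this position, since a 2.0-fold lower number from compound 3 to compound 4 (0.30 log units; within the scatter) stays within the scatter, so moving from 2,4-difluorophenyl to 2,3,4,5,6-pentafluorophenyl brings no change that can be read here, even though compound 4 alone lies beyond the scatter of both compound 1 and compound 2. No supporting data are available to explain these differences.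

The compounds shown leave open how a phenyl ring without substituents, or one carrying an amine or a carboxylic acid, would compare at this position, and whether a longer saturated chain could take the place of the aromatic ring. From the compounds shown here alone, all four compounds share one core, so it also remains open whether the same order would hold if any other part of that core were changed.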